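Fluorine Pair on the Benzyl Arm of Compound 3

The source may report more compounds than this note shows. Statements on the series, on what has been measured and on what is new or still open speak of the compounds shown alone.

Of the compounds shown here, three have been measured in a functional assay on CHO cells for antagonist activity at prostaglandin E2 receptor EP4 subtype (Homo sapiens), read by calcium flux, with a stated time of 15 min; on this read-out lower numbers stand for stronger inhibition and higher numbers for weaker inhibition. Compound 1 `CCc1c(C(=O)N[C@@H](C)c2ccc(C(=O)O)cc2)nnn1Cc1ccc(C(F)(F)F)cc1` reaches only the limit of this assay, giving > 10000 nM. That limit is the limit of > 10000 nM in this assay, at which 1 of the 3 values shown sits. Compound 2 `CCCc1nnn(Cc2ccc(C(F)(F)F)cc2)c1C(=O)N[C@@H](C)c1ccc(C(=O)O)cc1` gives 68.8 nM in this assay. Compound 3 `C[C@H](NC(=O)c1c(-c2ccccc2)nnn1Cc1ccccc1)c1ccc(C(=O)O)cc1` gives 647 nM in this assay, which places it as the higher of the two plain numbers; the nearest number is that of compound 2, which lies lower by a gap beyond the usual scatter. Compound 2 and compound 3 differ in more than one place, so their two values show only that they sit apart, not which change is responsible.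

Compound 4 `C[C@H](NC(=O)c1c(-c2ccccc2)nnn1Cc1ccc(F)c(F)c1)c1ccc(C(=O)O)cc1` is not yet measured. It differs from compound 3 by 3,4-difluorophenyl in place of phenyl on a saturated chain carbon bound to an aromatic nitrogen. Among the measured compounds shown here, no measured pair differs in exactly this place, so no direct step is available to read from. On that footing the step from compound 3 to compound 4 is expected to be a 2.2-fold lower number from compound 3 to compound 4 (0.33 log units; beyond the scatter), a modest move toward stronger inhibition that could still fall within the scatter. Compound 4 is therefore estimated to give 300 nM in this assay, with a likely range from 100 nM to 1200 nM.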

Compound 4, half-maximal inhibitory concentration: 148 nM
For compound 4 the middle estimate is 2.0-fold (0.31 log units) above the measured one, within the range that was stated.
By their numbers in this assay, from the lowest: compound 2; then compound 4; then compound 3. At a limit, above all of these: compound 1.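

In this assay, replacing benzyl with 3,4-difluorobenzyl, on a saturated chain carbon bound to an aromatic nitrogen, gives a 4.4-fold lower number from compound 3 to compound 4 (0.64 log units; beyond the scatter). This is the first change shown that sits in one place alone, so this size of shift can be assigned to the fluorine pair, whereas the gap between compound 2 and compound 3 could not be assigned to any single change. It shows that the benzyl arm is not indifferent to substitution in this series, though no measurement shown here bears on how the two fluorines bring this about.

The compounds shown leave open whether a single fluorine would give the same shift, and whether a pair of chlorines or a methoxy group on the benzyl arm would move the number in the same direction or the other way. They also leave open whether the step would hold in a compound that carries the propyl chain of compound 2 in place of the phenyl group of compound 3.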